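Amide replacement at the carbonyl of compound 2

The compounds below may be only part of what the source reports. "The series", "measured", "known", "first", "only" and "open" are said of these compounds alone.

Measured so far in a functional assay on A2780 cells (Homo sapiens) for antiproliferative activity, read by fluorescence, with a stated time of 72 h; a higher number here means a weaker inhibitor, a lower number a stronger inhibitor:
compound 1 `CC1(C)c2[nH]nc(NC(=O)c3ccc(F)cc3)c2CN1C(=O)C1CCN(C2CC2)CC1`: 380 nM
compound 2 `CCCNC(=O)Nc1n[nH]c2c1CN(C(=O)C1CCN(C)CC1)C2(C)C`: 650 nM

Compound 2 gives the higher of the two numbers, but its gap to compound 1 lies within the scatter, so the two stand level. Compound 3 `CN1CCC(C(=O)N2Cc3c(NC(=O)c4ccc(F)c(F)c4)n[nH]c3C2(C)C)CC1` carries 3,4-difluorophenyl in place of propylamino on a carbonyl carbon. Among the measured compounds shown here, no measured pair tracks this change directly. Compound 1, which holds an aryl amide on the same carbonyl, gives 380 nM and serves as the nearest guide. The step of a 1.9-fold lower number from compound 2 to compound 3 (0.27 log units; within the scatter) is expected to stay within the scatter, leaning if anything to a lower number. Compound 3 is expected at 350 nM, within 150 nM to 800 nM.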

Compound 3, half-maximal inhibitory concentration: 100 nM
Estimate against measurement, compound 3: 3.5-fold (0.54 log units) above; the measured number lies below the stated range.
By their numbers in this assay, from the lowest: compound 3; then compounds 1 and 2 (each within the scatter of the next).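

In this assay, 3,4-difluorophenyl in place of propylamino on a carbonyl carbon gives a 6.5-fold lower number from compound 2 to compound 3 (0.81 log units; beyond the scatter), so this position responds to the change. The step removes a chain carrying a hydrogen-bond donor and adds a six-membered aromatic ring, and a single pair cannot separate these two differences. Nothing measured here bears on a cause for the step. Open, on these data alone, is whether unsubstituted phenyl on this carbonyl carbon matches 3,4-difluorophenyl. Also open, as far as these compounds go, is whether anilino, which keeps the nitrogen and adds the ring, tracks the aryl group or propylamino.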